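Nitrile to Fluorine on the Outer Phenyl Amide

This account rests on a few compounds, and the source may have more. Where it says the series, first, only, none or still open, it means among the compounds named here.

Compound 3 `CN(C)C(=O)c1cc2cnc(Nc3ccc(NC(=O)C4(C(=O)Nc5ccc(C#N)cc5)CC4)cc3)nc2n1C1CCCC1` stands highest of the three measured compounds in a functional assay on A549 cells (Homo sapiens) for inhibition, read by CCK-8 assay, with a stated time of 72 h, tested at 1 uM (a lower number here means less inhibition of growth, a higher number more inhibition of growth at the concentration tested), where compound 3 gives 86.1%. Compound 2 `CN(C)C(=O)c1cc2cnc(Nc3ccc(NC(=O)C4(C(=O)Nc5ccc(Cl)cc5)CC4)cc3)nc2n1C1CCCC1` gives 24.7% and compound 1 `COC(=O)c1cccc(NC(=O)C2(C(=O)Nc3ccc(Nc4ncc5cc(C(=O)N(C)C)n(C6CCCC6)c5n4)cc3)CC2)c1` gives 10.5%, so the step of a number 61.4 percentage points higher from compound 2 to compound 3 (beyond the scatter) and the step of a number 75.6 percentage points higher from compound 1 to compound 3 (beyond the scatter) set compound 3 well apart from both. Compound 4 `CN(C)C(=O)c1cc2cnc(Nc3ccc(NC(=O)C4(C(=O)Nc5ccc(F)cc5)CC4)cc3)nc2n1C1CCCC1` differs from compound 3 in one place: fluoro in place of cyano on an aromatic carbon. The measured step that bears most directly on this change is a number 61.4 percentage points higher from compound 2 to compound 3 (beyond the scatter), in which cyano in place of chloro raised the read-out sharply; going back from cyano to another halogen, fluoro, is therefore expected to lower it beyond the scatter, toward the level of compound 2. Compound 4 is estimated at 25% with a range from 8% to 50%. The expected step is a number 61.1 percentage points lower from compound 3 to compound 4 (beyond the scatter).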

Compound 4, percent growth inhibition at one concentration: 86.6%
Estimate against measurement, compound 4: 61.6 percentage points below, outside the stated range (above it).
By their numbers in this assay, from the lowest: compound 1; then compound 2; then compounds 3 and 4 (each within the scatter of the next).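

In this assay, fluoro and cyano on this aromatic carbon cannot be told apart (a number 0.5 percentage points higher from compound 3 to compound 4 (within the scatter)), so a nitrile is not needed for the high read-out, and the change from cyano to a halogen does not by itself lower it. Chloro stands apart from fluoro at the same carbon (a number 61.9 percentage points higher from compound 2 to compound 4 (beyond the scatter)), and 4-fluorophenyl also stands well clear of 3-(methoxycarbonyl)phenyl (a number 76.1 percentage points higher from compound 1 to compound 4 (beyond the scatter)). Nothing given here accounts for this split between the two halogens. Open, going by these compounds, is how an amine, a carboxylic acid or a methoxy group would read at this carbon. Also open, on these data alone, is whether compound 3 and compound 4 would still match across a range of concentrations.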